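This account rests on a few compounds, and the source may have more. Where it says the series, first, only, none or still open, it means among the compounds named here.

Compound 1 `O=C1CC(c2ccccc2F)C(=O)N1CN1CCN(c2ccc(Cl)cc2)CC1` and compound 2 `O=C1CC(c2ccccc2F)C(=O)N1CN1CCN(c2cccc(C(F)(F)F)c2)CC1` share one core and differ only in the group on the ring nitrogen: 3-(trifluoromethyl)phenyl in place of 4-chlorophenyl on an amine nitrogen in a ring. In a functional assay on the whole organism (strain CF-1 albino) with Mus musculus as the target, with a stated time of 4 h (a higher number here means that more compound is needed for the effect, a lower number that less compound is needed), compound 1 gives 100 mg/kg, and compound 2 gives 100 mg/kg, so that exchange made no change at the digits printed from compound 1 to compound 2 (within the scatter). Compound 3 `O=C1CC(c2ccccc2Br)C(=O)N1CN1CCN(c2ccc(Cl)cc2)CC1` keeps the 4-chlorophenyl of compound 1 but carries a different halogen on the other aromatic ring: bromo in place of fluoro on an aromatic carbon. In this assay compound 3 gives 300 mg/kg, a step of a 3.0-fold higher number from compound 1 to compound 3 (0.48 log units; beyond the scatter), and among the three measured compounds compound 3 needs the most material.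

Compound 4 `O=C1CC(c2ccccc2Br)C(=O)N1CN1CCN(c2cccc(C(F)(F)F)c2)CC1` is not yet measured. It stands to compound 3 as compound 2 stands to compound 1, with the same group leaving and entering at the same place: 3-(trifluoromethyl)phenyl in place of 4-chlorophenyl on an amine nitrogen in a ring. The two cores differ in the way shown between compound 1 and compound 3, and the places where the exchange happens read the same word for word, so the change is the same change, seen for the second time. Because the earlier exchange made no change at the digits printed from compound 1 to compound 2 (within the scatter), compound 4 is expected to sit close to compound 3, with an estimated step of no change at the digits printed from compound 3 to compound 4 (within the scatter). Compound 4 is therefore estimated at 300 mg/kg, with a plausible range from 100 mg/kg to 1000 mg/kg, resting on a single earlier instance of this exchange.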

Compound 4, minimum effective dose: 300 mg/kg
Estimate against measurement, compound 4: no gap at the digits printed, within the range that was stated.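

On the bromo core, 3-(trifluoromethyl)phenyl in place of 4-chlorophenyl gives no change at the digits printed from compound 3 to compound 4 (within the scatter) in this assay, and this matches what the same exchange did on the fluoro core: the same change on two cores in this assay, no change at the digits printed (within the scatter) from compound 1 to compound 2 and no change at the digits printed (within the scatter) from compound 3 to compound 4, 1.0-fold (0.00 log units) apart, within the scatter of two such steps. The halogen exchange also carries over, since bromo in place of fluoro on the core that bears 3-(trifluoromethyl)phenyl gives a 3.0-fold higher number from compound 2 to compound 4 (0.48 log units; beyond the scatter) and so repeats the earlier step: the same change on two cores in this assay, a 3.0-fold higher number (0.48 log units; beyond the scatter) from compound 1 to compound 3 and a 3.0-fold higher number (0.48 log units; beyond the scatter) from compound 2 to compound 4, 1.0-fold (0.00 log units) apart, within the scatter of two such steps. Across these four compounds, each change therefore keeps its size when moved to the other core, which makes the effect of one change a fair guide to the same change elsewhere in this small set, but each comparison rests on only two cores and a single whole-animal read-out, so this does not show a rule for the wider series or explain why the steps match.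

The compounds shown leave open whether the same carrying over would hold for other groups on the aromatic ring of the core, such as chloro or methoxy in place of fluoro and bromo. They also leave open what an unsubstituted phenyl or a benzyl group would do on the ring nitrogen in place of the two substituted phenyl groups.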